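Thiazole for methylpyrazole on the fused benzo ring

A few compounds are considered here, and "the series" means these few. Any claim that something is new, unique, unknown or untested is made for them only; others in the source may bear on it.

Measured so far in a functional assay on CHO cells for agonist activity at Alpha-1B adrenergic receptor (Homo sapiens), read by FLIPR and calcium flux; on this read-out lower numbers stand for an effect already at smaller amounts and higher numbers for an effect only at larger amounts of compound:
compound 1 `Cc1n[nH]cc1-c1cccc2c1CCC2c1ncc[nH]1`: 902 nM
compound 2 `Cn1cc(-c2cccc3c2CCC3c2ncc[nH]2)cn1`: a limit, > 10000 nM

Compound 2 sits at the top of the numbers shown; its value is only a limit of the assay, (the limit of > 10000 nM in this assay, at which 1 of the 2 values shown sits). Within the data shown here, the one measured step, an at least 11-fold higher number from compound 1 to compound 2 (1.04 log units; beyond the scatter), already moved the series out of the measurable range, so compound 2 is the weaker-read end of the pair.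

Compound 3 `c1cc(-c2nccs2)c2c(c1)C(c1ncc[nH]1)CC2` differs from compound 2 by 1,3-thiazol-2-yl in place of 1-methyl-1H-pyrazol-4-yl on an aromatic carbon. Among the measured compounds shown here, no measured step touches this particular swap; the only step known concerns the pyrazole substitution pattern, not a change of ring type, so the direction for compound 3 cannot be read from it. The working expectation is that compound 3 returns toward the measurable range, an at least 2.0-fold lower number from compound 2 to compound 3 (0.30 log units; that floor lies within the scatter), with a real chance that it stays at the limit. Compound 3 is estimated at 5000 nM, in the range 1000 nM to 20000 nM.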

Compound 3, half-maximal effective concentration: > 10000 nM
Compound 3: no number, only a limit; the forecaster's own chance of this, stated with the estimate: 40%; middle value at least 2.0-fold (0.30 log units) away from the limit.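

In this assay compound 3 gives > 10000 nM, which is a limit of the assay. Putting 1,3-thiazol-2-yl in place of 3-methyl-1H-pyrazol-4-yl on the same aromatic carbon gives an at least 11-fold higher number from compound 1 to compound 3 (1.04 log units; beyond the scatter), so a change of ring type, and not only the shift of methyl within the pyrazole, also ends without a measurable number. Compound 1 remains the only one of the three with a number, and the step between compound 2 and compound 3 cannot be read, with both sitting at the same ceiling: the limit of > 10000 nM in this assay, at which 2 of the 3 values shown sit.

Going by these compounds, how far compound 2 and compound 3 lie beyond that limit stays open. Also open, on these data alone, is whether an unsubstituted 1H-pyrazol-4-yl or a simple amine on this aromatic carbon would give a measurable number.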